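The source may hold more compounds than are shown below. What is called first, only, known or untested is meant among the compounds shown, and "the series" means these compounds.

Compound 1 `CCCCCCCCCCCC(=O)N[C@H](CCC(=O)NC(CCCC(N)C(=O)O)C(=O)O)C(=O)O` gives, in a functional assay on HEK293 cells for agonist activity at Nucleotide-binding oligomerization domain-containing protein 1 (Homo sapiens), read by spectrophotometry (a lower number here means that less compound is needed, a higher number that more compound is needed for the effect), 0.027 nM, the lowest of the three numbers obtained so far. The other two measured compounds each change the far end of the chain: compound 2 `CCCCCCCCCCCC(=O)N[C@H](CCC(=O)NC(CCCC1NC(N)=NC1=O)C(=O)O)C(=O)O` gives 1.31 nM, and compound 3 `CCCCCCCCCCCC(=O)N[C@H](CCC(=O)NC(CCCC(NC(=N)N)C(=O)O)C(=O)O)C(=O)O` gives 0.622 nM. The steps involved are a 49-fold higher number from compound 1 to compound 2 (1.69 log units; beyond the scatter) and a 23-fold higher number from compound 1 to compound 3 (1.36 log units; beyond the scatter), with a 2.1-fold lower number from compound 2 to compound 3 (0.32 log units; beyond the scatter) between the two variants. Compound 4 `CCCCCCCCCCCC(=O)NCCCC(=O)NC(CCCC(N)C(=O)O)C(=O)O` is not yet measured. The change from compound 1 is hydrogen in place of carboxy on a saturated chain carbon bound to an amide-type nitrogen and a saturated chain carbon. Among the measured compounds shown here, none of the measured steps bears directly on this position; all three concern the group on the saturated chain carbon four bonds along the chain from the amide-type nitrogen, so they give no direct guide to the size of this step. What they do show is that every departure from compound 1 so far has raised the number, and by a large margin. Removing the carboxy is expected to do the same, with a 37-fold higher number from compound 1 to compound 4 (1.57 log units; beyond the scatter). Compound 4 is therefore estimated at 1 nM, within a range of 0.1 nM to 30 nM.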

Compound 4, half-maximal effective concentration: 0.504 nM
Estimate against measurement, compound 4: 2.0-fold (0.30 log units) above, within the range that was stated.
By their numbers in this assay, from the lowest: compound 1; then compounds 4 and 3 (each within the scatter of the next); then compound 2.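

In this assay, among the compounds shown here, hydrogen in place of carboxy on a saturated chain carbon bound to an amide-type nitrogen and a saturated chain carbon gives a 19-fold higher number from compound 1 to compound 4 (1.27 log units; beyond the scatter), the first measured step at this position. The series therefore depends on this carboxy as well as on the far end of the chain, although the number stays measurable without it, with compound 4 at 0.504 nM. Nothing available accounts for the size of this step.

On these data alone, whether the carboxylic acid itself is needed at this position remains open, since a methyl ester, a primary amide, a hydroxymethyl group or a carboxymethyl group could separate the acid from the mere presence of a substituent. Also open, as far as these compounds go, is whether the step carries over to compounds that bear the far-end groups of compound 2 or compound 3.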